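Chloro for nitro on the compound 1 scaffold

The source may hold more compounds than are shown below. What is called first, only, known or untested is meant among the compounds shown, and "the series" means these compounds.

Of the compounds shown here, two anchor the series so far. Going by the values given here, in a functional assay on DU-145 cells (Homo sapiens) for antiproliferative activity, read by MTT assay, with a stated time of 72 h (on this read-out higher numbers stand for weaker inhibition and lower numbers for stronger inhibition), compound 1 `O=C1OCC[C@@H]1NC(=S)SCCOc1ccc([N+](=O)[O-])cc1` gives 31000 nM, the only actual number available. Compound 2 `O=C(CNc1ccccc1)N[C@H]1CCOC1=O` reads > 64000 nM in this assay, and this is a limit of the assay, not a number. Compound 1 therefore stands alone as a measured reference, with no second number to set it against.

The next compound is compound 3 `O=C1OCC[C@@H]1NC(=S)SCCOc1ccc(Cl)cc1`, which keeps the core of compound 1 and changes one substituent: chloro in place of nitro on an aromatic carbon. In words, this is chloro in place of nitro on an aromatic carbon, para to a large group.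

Among the compounds with values here, no measured pair shows what such a swap does, so the expectation is broad. Within the data shown here, the only guide is compound 1 at 31000 nM, and no step beyond the usual scatter is favoured in this assay, in either direction. The expected change is a 1.1-fold lower number from compound 1 to compound 3 (0.04 log units; within the scatter), an estimate that carries wide uncertainty. Compound 3 is estimated at 28000 nM, with an expected range from 11000 nM to 64000 nM.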

Compound 3, half-maximal inhibitory concentration: > 64000 nM
Compound 3 gave a limit, no number; the forecaster's own chance of this, stated with the estimate: 15%; middle value at least 2.2-fold (0.35 log units) from the limit.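

Chloro in place of nitro on an aromatic carbon, para to a large group, gives an at least 2.0-fold higher number from compound 1 to compound 3 (0.31 log units; beyond the scatter) in this assay, and this is the first step in the series that can be read. Going by these compounds alone, this position therefore matters for the read-out: on the core of compound 1, nitro is so far the only group here with an actual number, while chloro takes compound 3 to a limit of the assay, not a number. Only a minimum can be given for this step, and its full size stays unknown, because compound 3 sits at that limit: the limit of > 64000 nM in this assay, at which 2 of the 3 values shown sit.

The compounds shown leave open whether other groups at this position, such as a nitrile, a methoxy group or an amine, keep a number on the scale, and whether any of them gives a lower number than compound 1 at 31000 nM. Also open, going by these compounds, is what a longer chain in place of the present one would do on the shared core, as a single step at one position says nothing about other places.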